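Swapping Morpholine for Pyrrolidine on the Thiocarbonyl Carbon

This account rests on a few compounds, and the source may have more. Where it says the series, first, only, none or still open, it means among the compounds named here.

Of the compounds shown here, three sharing one core have been measured in a functional assay on A-431 cells (Homo sapiens) for cytotoxicity, read by MTT assay, with a stated time of 72 h, tested at 3 uM; a lower number here means less inhibition of growth, a higher number more inhibition of growth at the concentration tested. Compound 1 `N/C(=N\NC(=S)N1CCOCC1)c1ccc(F)cn1` gives 47%. Compound 2 `N/C(=N\NC(=S)N1CCOCC1)c1ccccn1` gives 43.1%, and compound 3 `Cc1cccc(/C(N)=N/NC(=S)N2CCCC2)n1` gives 47.2%. Compound 1 lies close to both others: compound 3 is nearest and compound 2 furthest, and each gap is within the scatter. Among the measured compounds shown here, the only step between compounds that differ in a single place is a number 3.9 percentage points lower from compound 1 to compound 2 (within the scatter), hydrogen in place of fluoro on an aromatic carbon, and it too is within the scatter.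

Compound 4 `N/C(=N\NC(=S)N1CCCC1)c1ccc(F)cn1` has not yet been measured. It differs from compound 1 by pyrrolidin-1-yl in place of morpholin-4-yl on a thiocarbonyl carbon. For the measured compounds named here, no measured step alters this group alone. Going by the values given here, compound 3 does carry pyrrolidin-1-yl, but it differs from compound 1 in more than one place, so its value shows only that a pyrrolidin-1-yl compound reached a number much like that of compound 1. Among the compounds with values here, with the one measured step within the scatter and nothing pointing to a larger effect, no step beyond the scatter is expected in this assay. Compound 4 is therefore expected to give 47%, within a range from 35% to 58%. The expected step is no change at the digits printed from compound 1 to compound 4 (within the scatter).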

Compound 4, percent growth inhibition at one concentration: 72.2%
Beside the measured number, compound 4's estimate is 25.2 percentage points below it; measured number above the stated range.
By their numbers in this assay, from the lowest: compounds 2, 1 and 3 (each within the scatter of the next); then compound 4.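

Pyrrolidin-1-yl in place of morpholin-4-yl on a thiocarbonyl carbon gives a number 25.2 percentage points higher from compound 1 to compound 4 (beyond the scatter) in this assay, so this position can move the number in a way the earlier compounds gave no sign of. Among the compounds shown here, the only earlier step with a single difference, a number 3.9 percentage points lower from compound 1 to compound 2 (within the scatter), concerned a different place on the shared core. The change swaps a six-membered ring with 2 hetero atoms for a five-membered ring with 1 hetero atom, and this single pair cannot separate the loss of the oxygen from the change in ring size. No evidence at hand accounts for the step.

Open, going by these compounds, is whether a piperidin-1-yl group, which keeps the six-membered ring without the oxygen, or an open-chain dimethylamino group would hold the higher number. Also open, on these data alone, is whether the step would persist with hydrogen in place of fluoro on the aromatic carbon.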